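A few compounds are considered here, and "the series" means these few. Any claim that something is new, unique, unknown or untested is made for them only; others in the source may bear on it.

Measured so far in a functional assay on SK-MEL-2 cells (Homo sapiens) for inhibition, read by sulforhodamine B assay, with a stated time of 48 h, tested at 100 uM; a lower number here means a stronger effect, a higher number a weaker effect of the compound at the concentration tested:
compound 1 `COc1cc(Cl)cc(-c2nn(-c3cccc(NC(=O)Nc4ccc(Cl)c(C(F)(F)F)c4)c3)cc2-c2ccncc2)c1` — -85%
compound 2 `COc1cc(Cl)cc(-c2nn(-c3cccc(NC(=O)Nc4ccc(Cl)c(Cl)c4)c3)cc2-c2ccncc2)c1` — -70%
compound 3 `COc1cc(Cl)cc(-c2nn(-c3cccc(NC(=O)Nc4cccc(C(F)(F)F)c4)c3)cc2-c2ccncc2)c1` — -68%

Compound 3 has the highest of the three numbers in this assay; compound 2 sits within the scatter of it (a number 2 percentage points higher from compound 2 to compound 3 (within the scatter)), while compound 1 stands beyond it (a number 17 percentage points higher from compound 1 to compound 3 (beyond the scatter)). Compound 4 `COc1cc(Cl)cc(-c2nn(-c3cccc(NC(=O)c4cccc(C(F)(F)F)c4)c3)cc2-c2ccncc2)c1` differs from compound 3 in one place: 3-(trifluoromethyl)phenyl in place of (3-(trifluoromethyl)phenyl)amino on a carbonyl carbon. Among the compounds with values here, no measured step touches this place; a number 15 percentage points higher from compound 1 to compound 2 (beyond the scatter) and a number 17 percentage points higher from compound 1 to compound 3 (beyond the scatter) concern only chloro and trifluoromethyl exchanges on an aromatic carbon, both modest. The measured steps therefore give no basis for a shift of a particular size, and no step beyond the scatter is expected, a number 6 percentage points higher from compound 3 to compound 4 (within the scatter). Compound 4 is estimated at -62% in this assay, with a range from -85% to -35%.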

Compound 4, a percentage reported as activity, at one concentration (the size of the read-out at that concentration, not a potency): 47%
Compound 4: middle estimate off by 109 percentage points, on the low side; the measured number lies above the stated range.
By their numbers in this assay, from the lowest: compound 1; then compounds 2 and 3 (each within the scatter of the next); then compound 4.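

Exchanging (3-(trifluoromethyl)phenyl)amino for 3-(trifluoromethyl)phenyl on the carbonyl carbon removes one nitrogen and one hydrogen-bond donor, and in this assay this gives a number 115 percentage points higher from compound 3 to compound 4 (beyond the scatter) and moves the read-out from negative to positive. The steps of a number 117 percentage points higher from compound 2 to compound 4 (beyond the scatter) and a number 132 percentage points higher from compound 1 to compound 4 (beyond the scatter) run the same way and are large, whereas the chloro and trifluoromethyl exchanges were modest at most. No measurement shown accounts for the size of this change.

On these data alone, whether the nitrogen itself or its hydrogen matters remains open. A methylamino or methylene link on the carbonyl carbon would separate the two.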